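Replacing a Bromophenyl with a Methoxyphenyl on the Sulfonamide

The source may report more compounds than this note shows. Statements on the series, on what has been measured and on what is new or still open speak of the compounds shown alone.

Compound 3 `O=C1NCCN1c1ccc(S(=O)(=O)Nc2cccc(Br)c2)cc1` gives 100 nM in a functional assay on MCF7 cells (Homo sapiens) for antiproliferative activity, read by sulforhodamine B assay, with a stated time of 48 h (a lower number here means a stronger inhibitor, a higher number a weaker inhibitor), the lowest of the two numbers shown. Compound 1 `CCc1ccc(NS(=O)(=O)c2ccc(N3CCNC3=O)cc2)cc1` gives 810 nM in this assay, and the step of an 8.1-fold lower number from compound 1 to compound 3 (0.91 log units; beyond the scatter) sets the two apart. Compound 2 `CC(C)(C)c1ccc(NS(=O)(=O)c2ccc(N3CCNC3=O)cc2)cc1` gives in this assay only a limit, > 1000 nM. Compound 4 `COc1ccc(NS(=O)(=O)c2ccc(N3CCNC3=O)cc2)cc1` is not yet measured. It differs from compound 3 by 4-methoxyphenyl in place of 3-bromophenyl on a sulfonamide nitrogen. Among the measured compounds shown here, the one measured step that bears directly on this change is an 8.1-fold lower number from compound 1 to compound 3 (0.91 log units; beyond the scatter), which shows the 4-ethylphenyl well behind the 3-bromophenyl. The step of an at least 1.2-fold higher number from compound 1 to compound 2 (0.09 log units; that floor lies within the scatter), read against the limit (the limit of > 1000 nM in this assay, at which 1 of the 3 values shown sits), gives no sign that tert-butyl in place of ethyl improves matters. The 4-methoxyphenyl of compound 4 resembles the 4-ethylphenyl of compound 1 more than the 3-bromophenyl of compound 3, so a higher number than that of compound 3 is expected, with an estimated step of a 6.0-fold higher number from compound 3 to compound 4 (0.78 log units; beyond the scatter). In this assay compound 4 is therefore estimated at 600 nM, within 200 nM to 2000 nM.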

Compound 4, half-maximal inhibitory concentration: > 1000 nM
Compound 4 was reported as a limit; the forecaster's own chance of this, stated with the estimate: 30%; at least 1.6-fold (0.22 log units) between middle value and limit.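

In this assay, the 4-methoxyphenyl on the sulfonamide nitrogen falls clearly behind the 3-bromophenyl, an at least 10-fold higher number from compound 3 to compound 4 (1.00 log units; beyond the scatter). Against the 4-ethylphenyl the result gives only a floor, an at least 1.2-fold higher number from compound 1 to compound 4 (0.09 log units; that floor lies within the scatter), so methoxy and ethyl cannot be put in order. The step between compound 2 and compound 4 cannot be read, and the result adds a second compound to those that give only a limit: the limit of > 1000 nM in this assay, at which 2 of the 4 values shown sit.

From the compounds shown here alone, how far compound 2 and compound 4 actually lie past that limit stays open. Also open, going by these compounds, is whether the bromine or its place on the ring sets compound 3 apart, and how a 3-methoxyphenyl, a 4-bromophenyl or a 3-aminophenyl on the same sulfonamide nitrogen would stand in this assay.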